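The source may report more compounds than this note shows. Statements on the series, on what has been measured and on what is new or still open speak of the compounds shown alone.

The series is followed in an ADME assay on HepG2 2.2.15 cells (Homo sapiens) for cytotoxicity; on this read-out lower numbers stand for higher toxicity in this test and higher numbers for lower toxicity in this test. Compound 1 `Cc1ccc(C(=O)Nc2ncc(Cc3ccc(F)cc3)s2)cc1`, carrying an amide on the shared core, is recorded in this assay as "not toxic" (no number reported). Compound 2 `Cc1cc(C(C)C)ccc1OC(c1ccc(Cl)cc1)c1cnc(NC(=O)OC(C)(C)C)s1`, a carbamate on the same core, gives in this assay > 50000 nM, which is a limit of the test and not a number. Compound 3 `Clc1ccc(C(Oc2ccc3cc(Br)ccc3c2)c2cnc(NCC3CCOCC3)s2)cc1`, bearing a ((oxan-4-yl)methyl)amino group on the core, is recorded in this assay as "not toxic" (no number reported). Among the three values shown, one sits at the limit of > 50000 nM in this assay, at which 1 of the 3 values shown sits. Compound 3 itself thus stands without a single number, as one of two entries that give no figure. Among the compounds with values here, no step between two measured compounds is computed here; each pair differs in more than one place.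

Compound 4 `O=C(Nc1ncc(C(Oc2ccc3cc(Br)ccc3c2)c2ccc(Cl)cc2)s1)c1ccc(F)cc1F` differs from compound 3 by (2,4-difluorophenyl)carbonyl in place of (oxan-4-yl)methyl on a nitrogen on an aromatic ring. All three values shown point to low toxicity in this assay, and for compound 4 no step beyond the scatter is expected in either direction. Compound 4 is therefore estimated at 50000 nM in this assay, with a range from 20000 nM to 120000 nM, and the reported result may well again be a limit rather than a number.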

Compound 4, half-maximal cytotoxic concentration: "not toxic" (no number reported)
For compound 4 the study gives words and no number; there is nothing to compare the estimate with.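

In this assay, compound 3 and compound 4 are both recorded in words alone, so no step can be read for the change from ((oxan-4-yl)methyl)amino to ((2,4-difluorophenyl)carbonyl)amino. The compounds shown leave open at what concentration, if any, this series becomes toxic to these cells, and whether the group on the nitrogen alters that.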